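This account rests on a few compounds, and the source may have more. Where it says the series, first, only, none or still open, it means among the compounds named here.

Measured compounds in a physicochemical assay for lipophilicity, using the shake flask method; on this read-out lower numbers stand for lower lipophilicity and higher numbers for higher lipophilicity:
- compound 1 `Nc1ncnc(Oc2ccc(NC(=O)C3(C(=O)Nc4ccc(F)cc4)CC3)cc2F)c1/C=N/OCCCO`: 2.67
- compound 2 `Nc1ncnc(Oc2ccc(NC(=O)C3(C(=O)Nc4ccc(F)cc4)CC3)cc2F)c1/C=N/OCCO`: 2.37
- compound 3 `CC(C)(C)OC(=O)N/N=C/c1c(N)ncnc1Oc1ccc(NC(=O)C2(C(=O)Nc3ccc(F)cc3)CC2)cc1F`: 3.7

Compound 3 holds the highest value of the three in this assay; the nearest is compound 1, as shown by a number 1.03 log units higher from compound 1 to compound 3 (beyond the scatter), and the furthest is compound 2, as shown by a number 1.33 log units higher from compound 2 to compound 3 (beyond the scatter). Compound 1 and compound 2 differ only by a number 0.30 log units lower from compound 1 to compound 2 (within the scatter).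

Compound 4 `COCCCO/N=C/c1c(N)ncnc1Oc1ccc(NC(=O)C2(C(=O)Nc3ccc(F)cc3)CC2)cc1F` is not yet measured. It differs from compound 3 by 3-methoxypropoxy in place of (tert-butoxycarbonyl)amino on a double-bonded nitrogen. The two steps that bear on this change are the ones leading into compound 3, a number 1.03 log units higher from compound 1 to compound 3 (beyond the scatter) and a number 1.33 log units higher from compound 2 to compound 3 (beyond the scatter), both large and both running from an alkoxy substituent on that nitrogen up to the (tert-butoxycarbonyl)amino group. Compound 4 carries the 3-methoxypropoxy group, related to the 3-hydroxypropoxy group of compound 1, so a step downward from compound 3 is expected, though smaller than the reverse of a number 1.03 log units higher from compound 1 to compound 3 (beyond the scatter). The expected step is a number 0.50 log units lower from compound 3 to compound 4 (beyond the scatter). Compound 4 is thus estimated at 3.2, with a range from 2.8 to 3.6.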

Compound 4, partition coefficient: 3.18
For compound 4 the middle estimate is 0.02 log units above the measured one; low and high end bracket the measured number.
By their numbers in this assay, from the lowest: compounds 2 and 1 (each within the scatter of the next); then compound 4; then compound 3.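

In this assay, methyl in place of hydrogen on an oxygen on a saturated carbon gives a number 0.51 log units higher from compound 1 to compound 4 (beyond the scatter), so a change at the end of this chain can move the number beyond the scatter, which the shortening in a number 0.30 log units lower from compound 1 to compound 2 (within the scatter) did not do. The combined change of chain length and end group gives a number 0.81 log units higher from compound 2 to compound 4 (beyond the scatter), while the return from (tert-butoxycarbonyl)amino to 3-methoxypropoxy on the double-bonded nitrogen gives a number 0.52 log units lower from compound 3 to compound 4 (beyond the scatter), leaving compound 4 in a place of its own between compound 1 and compound 3. No supporting data bear on the origin of these steps.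

As far as these compounds go, whether methyl on the hydroxy of the shorter chain, as in 2-methoxyethoxy, would give a step of similar size remains open. Also open, from the compounds shown here alone, is how a terminal amine, a carboxylic acid or a longer methoxyalkoxy chain would read at this nitrogen.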